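Extending the ester chain of compound 2

The compounds below may be only part of what the source reports. "The series", "measured", "known", "first", "only" and "open" are said of these compounds alone.

For the measured compounds named here, in a functional assay on HeLa cells (Homo sapiens) for cytotoxicity, read by neutral red uptake, with a stated time of 3 days (a higher number here means a weaker inhibitor, a lower number a stronger inhibitor), compound 2 (`CCCCCC(=O)OCc1c(F)c(N)c2c(=O)cc(-c3ccc(N)c(F)c3)oc2c1F`) gives 34000 nM as the only actual number so far. Compound 1 (`CCOC(=O)c1c(F)c(N)c2c(=O)cc(-c3ccc(N)c(F)c3)oc2c1F`) gives > 100000 nM in this assay and this value is a limit of the assay.

Compound 3 (`CCCCCCCCCCCCCCCCCC(=O)OCc1c(F)c(N)c2c(=O)cc(-c3ccc(N)c(F)c3)oc2c1F`) differs from compound 2 by dodecyl in place of hydrogen on a saturated chain carbon, five bonds along the chain from a carbonyl carbon and so carries dodecyl in place of hydrogen on a saturated chain carbon, five bonds along the chain from a carbonyl carbon.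

Going by the values given here, one measured step bears on this, and only indirectly: an at least 2.9-fold lower number from compound 1 to compound 2 (0.46 log units; beyond the scatter). That step puts ((pentylcarbonyl)oxy)methyl in place of ethoxycarbonyl and does not extend an existing chain. No step beyond the scatter is therefore expected in this assay, although a result reported only as a limit remains possible.

The estimate amounts to a 1.6-fold higher number from compound 2 to compound 3 (0.21 log units; within the scatter) as the expected step. Compound 3 is expected at 55000 nM within an estimated range of 18000 nM to 100000 nM in this series.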

Compound 3, half-maximal inhibitory concentration: > 100000 nM
Compound 3: a limit, no number (the forecaster's own chance of this, stated with the estimate: 40%); middle value at least 1.8-fold (0.25 log units) from the limit.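

In this assay, dodecyl in place of hydrogen on a saturated chain carbon, five bonds along the chain from a carbonyl carbon, gives an at least 2.9-fold higher number from compound 2 to compound 3 (0.46 log units; beyond the scatter). Compound 3 gives > 100000 nM, which is a limit of the assay and not a number. The earlier step exchanged the whole group on the aromatic carbon, whereas this one shows that a change confined to the chain, with the ester link kept, is enough to return the reading to the limit, and the true size of the step stays unknown because the value sits at that limit: the limit of > 100000 nM in this assay, at which 2 of the 3 values shown sit.

Open, from the compounds shown here alone, is how the number runs with shorter additions at the same carbon, such as butyl or hexyl. Also open, going by these compounds, is whether a chain ending in an amine or a carboxylic acid follows dodecyl or stays with the unsubstituted chain.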